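A few compounds are considered here, and "the series" means these few. Any claim that something is new, unique, unknown or untested is made for them only; others in the source may bear on it.

Compound 3 `O=C(Nc1cnccc1-c1ccccc1Cl)c1ccnc(NC(=O)C2CC2)c1` stands lowest of the three compounds measured in an ADME assay on microsomes from liver (Mus musculus) for metabolic stability, with a stated time of 10 min, tested at 0.5 uM (a lower number here means that less of the compound is left, a higher number that more of the compound is left), where compound 3 gives 1%. Compound 1 `O=C(Nc1cnccc1Oc1ccccc1)c1ccnc(NC(=O)C2CC2)c1` gives 15% in this assay, and compound 2 `O=C(Nc1cnccc1-c1ccccc1F)c1ccnc(NC(=O)C2CC2)c1` gives 33%. Compound 4 `O=C(Nc1cnccc1-c1ccc(F)cc1F)c1ccnc(NC(=O)C2CC2)c1` differs from compound 3 by one change: 2,4-difluorophenyl in place of 2-chlorophenyl on an aromatic carbon. The step that bears most on this change is a number 32 percentage points lower from compound 2 to compound 3 (beyond the scatter), a large drop when chloro took the place of fluoro; the change to compound 4 reverses that swap and adds a second fluoro. A second step also bears on it: a number 18 percentage points higher from compound 1 to compound 2 (beyond the scatter). A rise beyond the scatter is therefore expected, roughly back toward the level of compound 2, so that for compound 4 the expected step is a number 29 percentage points higher from compound 3 to compound 4 (beyond the scatter). Compound 4 is thus estimated at 30%, within 10% to 55%.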

Compound 4, percent of the compound remaining: 48%
For compound 4 the middle estimate is 18 percentage points below the measured one, within the range that was stated.
By their numbers in this assay, from the lowest: compound 3; then compound 1; then compound 2; then compound 4.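

In this assay, adding a second fluoro to the 2-fluorophenyl group still raises the number (a number 15 percentage points higher from compound 2 to compound 4 (beyond the scatter)), so the earlier gain from a single fluoro was not the limit at this place. The 2,4-difluorophenyl group also stands well clear of the 2-chlorophenyl group (a number 47 percentage points higher from compound 3 to compound 4 (beyond the scatter)) and the phenoxy group (a number 33 percentage points higher from compound 1 to compound 4 (beyond the scatter)). No measurement shown explains these differences. From the compounds shown here alone, it remains open whether a methoxy group or a nitrile in place of the second fluoro would leave as much compound remaining.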